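The compounds below may be only part of what the source reports. "The series", "measured", "known", "first", "only" and "open" are said of these compounds alone.

Three related compounds have been tested in a functional assay on MDA-MB-231 cells (Homo sapiens) for antiproliferative activity, read by MTT assay, with a stated time of 48 h; on this read-out higher numbers stand for weaker inhibition and lower numbers for stronger inhibition. Compound 1 `COc1ccc(N(C)c2ccnc(Cl)n2)cc1Cl` gives 1380 nM in this assay. Compound 2 `COc1ccc(N(C)c2ccnc(Cl)n2)cc1[N+](=O)[O-]` gives 8120 nM in this assay. Compound 3 `COc1ccc(N(C)c2cc(C)nc(C)n2)cc1Cl` gives 1900 nM in this assay. The difference between the core of compound 1 and the core of compound 3 is not broken down here.

Compound 1 and compound 2 differ in one place: nitro in place of chloro on an aromatic carbon. This change made a step of a 5.9-fold higher number from compound 1 to compound 2 (0.77 log units; beyond the scatter) in this assay.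

Compound 4 `COc1ccc(N(C)c2cc(C)nc(C)n2)cc1[N+](=O)[O-]` has not yet been measured. It stands to compound 3 as compound 2 stands to compound 1: nitro in place of chloro on an aromatic carbon. The surroundings are described a little differently, the place being meta to a large group in compound 4 and meta to a group of 9 heavy atoms in compound 2, so this is the same kind of change rather than the same change. Because the earlier step was a 5.9-fold higher number from compound 1 to compound 2 (0.77 log units; beyond the scatter), a step of similar size is expected from compound 3, namely a 5.3-fold higher number from compound 3 to compound 4 (0.72 log units; beyond the scatter) in this assay. On that basis compound 4 is estimated to give about 10000 nM in this assay, with a plausible range from 4000 nM to 30000 nM.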

Compound 4, half-maximal inhibitory concentration: 3440 nM
Compound 4: middle estimate off by 2.9-fold (0.46 log units), on the high side; the whole stated range lies above it.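

In this assay, within the data shown here, putting nitro in place of chloro on an aromatic carbon gave a 1.8-fold higher number from compound 3 to compound 4 (0.26 log units; within the scatter), so on this core the swap produces no step that can be told apart from the usual scatter. The change therefore does not carry over at a fixed size between these two cores, and a step measured on one of them is a poor guide to the step on the other: the same change on two cores in this assay, a 5.9-fold higher number (0.77 log units; beyond the scatter) from compound 1 to compound 2 and a 1.8-fold higher number (0.26 log units; within the scatter) from compound 3 to compound 4, 3.2-fold (0.51 log units) apart, beyond the scatter of two such steps These two pairs do not show why the steps differ or which part of the cores matters, and they say nothing about cores beyond these two.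

The compounds shown leave open how other groups in this same place, such as an amine or a carboxylic acid, would behave on either core. They also leave open whether a smaller alteration of the core, such as a longer chain on only one of its carbons, would change the size of the nitro-for-chloro step.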